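The source may hold more compounds than are shown below. What is called first, only, known or untested is meant among the compounds shown, and "the series" means these compounds.

The measured compounds are:

Compound 1, `CC1(C)C=C(n2ccccc2=O)c2cc(C(=O)c3cccs3)ccc2O1`, which in a functional assay (trachea) with Rattus norvegicus as the target (on this read-out lower numbers stand for lower potency and higher numbers for higher potency (the scale is a negative logarithm)), gives 5.84.
Compound 2, `CC1(C)C=C(n2ccccc2=O)c2cc(C=C(C#N)C#N)ccc2O1`, which in this assay gives 6.3.
Compound 3, `CC(=O)Oc1ccc2c(c1)C(n1ccccc1=O)=CC(C)(C)O2`, which in this assay gives 4.97.

Compound 3 stands lowest of the three; compound 1 lies nearer to it, the step being a number 0.87 log units lower from compound 1 to compound 3 (beyond the scatter), and compound 2 further, with a number 1.33 log units lower from compound 2 to compound 3 (beyond the scatter). Between compounds 1 and 2 the step is a number 0.46 log units higher from compound 1 to compound 2 (beyond the scatter).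

Compound 4, `CC1(C)C=C(n2ccccc2=O)c2cc(OS(=O)(=O)F)ccc2O1`, is not yet measured. It differs from compound 3 by fluorosulfonyl in place of acetyl on an oxygen on an aromatic ring. For the measured compounds named here, none of the measured steps changes the acetyl of the acetoxy group; all three exchange the whole substituent on the aromatic carbon, and those exchanges moved the read-out by modest to large amounts. The present change is smaller in reach, touching only the group on the oxygen, so a step of about the scatter or somewhat beyond is expected, with no firm direction. The expected step is a number 0.23 log units higher from compound 3 to compound 4 (within the scatter). Compound 4 is therefore estimated at 5.2, within a range of 4.6 to 5.9.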

Compound 4, logarithm of the reciprocal of the active concentration, log(1/C): 7.22
The estimate for compound 4 lay 2.02 log units below the measured number, outside the stated range (above it).
By their numbers in this assay, from the lowest: compound 3; then compound 1; then compound 2; then compound 4.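

Exchanging only the group on the oxygen, with the rest of compound 3 unchanged, moves this assay by a large amount (a number 2.25 log units higher from compound 3 to compound 4 (beyond the scatter)), so this oxygen on an aromatic ring is a place where the attached group alone can decide the read-out. The (fluorosulfonyl)oxy group also surpasses both 2,2-dicyanoethenyl (a number 0.92 log units higher from compound 2 to compound 4 (beyond the scatter)) and (thiophen-2-yl)carbonyl (a number 1.38 log units higher from compound 1 to compound 4 (beyond the scatter)), which places compound 4 highest of the four. Nothing measured here explains this rise.

As far as these compounds go, only acetyl and fluorosulfonyl appear on this oxygen, so it remains open where a methanesulfonyl or a plain methyl group there would fall in this order. A comparison between methanesulfonyl and fluorosulfonyl would also show whether the rise depends on the fluorine or on the sulfonyl group.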